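A few compounds are considered here, and "the series" means these few. Any claim that something is new, unique, unknown or untested is made for them only; others in the source may bear on it.

Measured compounds:
Compound 1 `O=C(NCN1CCC(c2cccc[n+]2[O-])CC1)c1ccccc1` gives 63% in a functional assay on HEK293 cells for agonist activity at D(4) dopamine receptor (Homo sapiens), read by FLIPR; a lower number here means a smaller maximal response, a higher number a larger maximal response.
Compound 2 `c1ccc(C2CCN(Cc3nc4ccccc4[nH]3)CC2)nc1` gives 62% in this assay.

Compound 1 carries the higher of the two numbers, yet compound 2 lies only a single point lower, a gap within the scatter, so the two values show the same response and neither compound is set above the other. Compound 3 `C=Cc1cccc(C(=O)NCN2CCC(c3cccc[n+]3[O-])CC2)c1` is not yet measured. It differs from compound 1 in one place: vinyl in place of hydrogen on an aromatic carbon. Seen one bond further out, the change reads phenyl to 3-vinylphenyl. For the measured compounds named here, no pair of measured compounds shows this change, so the size of the step in this assay cannot be read from the data; the expectation is a step of no more than the usual scatter, in either direction. The step of a number 1 percentage points lower from compound 1 to compound 3 (within the scatter) is therefore estimated to be small. Compound 3 is expected to give 62%, between 45% and 80%.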

Compound 3, largest response reached (reported as efficacy), in percent of the reference or control that the assay uses: 63%
Beside the measured number, compound 3's estimate is 1 percentage points below it; the measured number falls inside the stated range.
By their numbers in this assay, from the lowest: compounds 2, 1 and 3 (each within the scatter of the next).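

The exchange of hydrogen for vinyl on an aromatic carbon, meta to a large group, gives no change at the digits printed from compound 1 to compound 3 (within the scatter) in this assay. For the compounds shown here, this is the first reading at this position, and it shows that the phenyl of compound 1 can become 3-vinylphenyl, adding two carbon atoms and a double bond outside the aromatic ring, with the maximal response held at the same level. Nothing available explains why the response stays level.

On these data alone, whether the response also holds with an amine, a carboxylic acid or a longer chain at this carbon remains open. So does whether vinyl would give the same reading on the other carbons of this ring.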